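The source may report more compounds than this note shows. Statements on the series, on what has been measured and on what is new or still open speak of the compounds shown alone.

Measured in a functional assay (spleen, spleen) for activation, with Mus musculus as the target; a higher number here means that more compound is needed for the effect, a lower number that less compound is needed:

Compound 1 `Nc1ncnc2c1nc(O)n2C1CCCC1` gives > 10 uM, a limit of the assay.
Compound 2 `COc1cccc(Cn2c(O)nc3c(N)ncnc32)c1` gives 10 uM.
Compound 3 `CCCNc1nc(N)c2nc(O)n(Cc3ccccc3)c2n1` gives 0.1 uM.

Of the two numbers in this assay, compound 3 holds the lower one; compound 2 sits well above it, a gap beyond the usual scatter of the measurement. Compound 1 contributes no number, only a limit, as shown in the limit of > 10 uM in this assay, at which 1 of the 3 values shown sits. Compound 4 `CCCSc1nc(N)c2nc(O)n(Cc3ccccc3)c2n1` is not yet measured. It differs from compound 3 in one place: propylsulfanyl in place of propylamino on an aromatic carbon. Among the measured compounds shown here, no pair of measured compounds shares this change, so there is no measured step to lean on. The core is kept as in compound 3, the most active measured compound here. The step from compound 3 to compound 4 is expected to be small, a drift toward a higher number that may stay within the scatter, a 3.0-fold higher number from compound 3 to compound 4 (0.48 log units; beyond the scatter). Compound 4 is therefore expected to give about 0.3 uM in this assay, with a range from 0.05 uM to 2 uM.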

Compound 4, minimum effective concentration: 0.01 uM
Estimate against measurement, compound 4: 30-fold (1.48 log units) above; the measured number lies below the stated range.
By their numbers in this assay, from the lowest: compound 4; then compound 3; then compound 2.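

In this assay, the aromatic carbon between two ring nitrogen atoms proves to be a position where the substituent matters, as propylsulfanyl in place of propylamino gives a 10-fold lower number from compound 3 to compound 4 (1.00 log units; beyond the scatter) and extends the series to its lowest number. Among the compounds shown here, this is the first step between compounds differing in one place, and it shows that the hydrogen-bond donor of propylamino is not needed for a low number at this position. Nothing measured in the compounds shown accounts for this step.

As far as these compounds go, whether the sulfur itself or the loss of the donor drives the step remains open, and a propoxy group at the same position would be needed to tell them apart. How a longer chain, such as butylsulfanyl, would fare there is also unknown.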